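The source may hold more compounds than are shown below. What is called first, only, known or untested is meant among the compounds shown, and "the series" means these compounds.

Measured in a physicochemical assay for solubility; on this read-out lower numbers stand for lower solubility and higher numbers for higher solubility:
- Compound 1 `CNC(=O)c1cc(C(=O)NCCC2CCOCC2)cn(Cc2ccccc2)c1=O` gives >= 127 ug/mL (a limit, not a number)
- Compound 2 `CNC(=O)c1cc(C(=O)NC(C)C)cn(Cc2ccccc2)c1=O` gives >= 136 ug/mL (a limit, not a number)
- Compound 3 `CNC(=O)c1cc(C(N)=O)cn(Cc2ccccc2)c1=O` gives 71 ug/mL

Among the compounds with values here, of these three results, only the one for compound 3 is an actual number, which makes it the firm point to start from. The next compound, compound 4 `CNC(=O)c1cc(C(=O)NCCO)cn(Cc2ccccc2)c1=O`, differs from it in one place: 2-hydroxyethyl in place of hydrogen on an amide-type nitrogen.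

Two measured steps make the same kind of change in reverse, leaving hydrogen on that nitrogen: an at least 1.7-fold lower number from compound 1 to compound 3 (0.25 log units; that floor lies within the scatter) and an at least 1.9-fold lower number from compound 2 to compound 3 (0.28 log units; that floor lies within the scatter). Both are only floors and both lie within the scatter, so neither proves a real change, though they point the same way. Between the two larger groups there is only a step that the two limits leave unreadable from compound 1 to compound 2. Read backwards, these steps suggest a modest rise in this assay, and a result reported only as a limit would be no surprise. The expected size is a 1.8-fold higher number from compound 3 to compound 4 (0.26 log units; within the scatter). For compound 4 the estimated value is 130 ug/mL, within an expected range of 80 ug/mL to 200 ug/mL.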

Compound 4, solubility: >= 140 ug/mL
Compound 4 gave a limit, no number; the forecaster's own chance of this, stated with the estimate: 55%; at least 1.0-fold (0.03 log units) between middle value and limit.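

At this amide-type nitrogen, 2-hydroxyethyl now joins isopropyl and 2-(oxan-4-yl)ethyl as groups whose result in this assay is reported only as a limit, while compound 3, with hydrogen there, has an actual number. The step is an at least 1.9-fold higher number from compound 3 to compound 4 (0.29 log units; that floor lies within the scatter), so this floor does not prove a real change on its own, though it points the same way as the two earlier floors, now with a group that has no ring. The result for compound 4 is a limit, not a number: the limit of >= 140 ug/mL in this assay, at which 1 of the 4 values shown sits.

The steps among compounds 1, 2 and 4 cannot be read, so these three groups cannot be ranked against one another. Still open, from the compounds shown here alone, is whether an amine or a carboxylic acid in place of the hydroxy group would point the same way.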